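The source may hold more compounds than are shown below. What is called first, only, known or untested is meant among the compounds shown, and "the series" means these compounds.

Compound 3 `Oc1ccc(-c2cc(-c3ccco3)cc(-c3cccc(O)c3)n2)cc1` gives 5170 nM in a functional assay on HeLa cells (Homo sapiens) for cytotoxicity, read by CCK-8 assay (a lower number here means a stronger inhibitor, a higher number a weaker inhibitor), the lowest of the two numbers shown. Compound 2 `Oc1cccc(-c2cc(-c3ccco3)cc(-c3cccc(O)c3)n2)c1` gives 5990 nM, and the step of a 1.2-fold lower number from compound 2 to compound 3 (0.06 log units; within the scatter) stays within the scatter. For compound 1 `Oc1ccc(-c2cc(-c3ccco3)cc(-c3ccccc3O)n2)cc1` this assay reports only a limit, > 50000 nM. The step of an at least 9.6-fold lower number from compound 1 to compound 3 (0.98 log units; beyond the scatter) is therefore bounded by the limit (the limit of > 50000 nM in this assay, at which 1 of the 3 values shown sits).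

Compound 4 `Oc1ccc(-c2cc(-c3ccoc3)cc(-c3cccc(O)c3)n2)cc1` differs from compound 3 by a single rearrangement: furan-3-yl in place of furan-2-yl on an aromatic carbon. Neither measured step touches the furan; both move a hydroxyl around a phenyl ring. Among the measured compounds shown here, no measured step bears on this change, so no direction is indicated and a step within the scatter is expected, a 1.0-fold lower number from compound 3 to compound 4 (0.01 log units; within the scatter). Compound 4 is estimated at 5000 nM, with a range from 2000 nM to 13000 nM.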

Compound 4, half-maximal inhibitory concentration: 3310 nM
Compound 4: the middle estimate sits 1.5-fold (0.18 log units) above what was measured, and the stated range covers the measured number.
By their numbers in this assay, from the lowest: compounds 4, 3 and 2 (each within the scatter of the next). At a limit, above all of these: compound 1.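

Among the compounds shown here, the first measured change at the furan, furan-3-yl in place of furan-2-yl opposite the ring nitrogen, gives a 1.6-fold lower number from compound 3 to compound 4 (0.19 log units; within the scatter), so in this assay this point of attachment does not separate the two compounds. The same atoms joined differently therefore leave the number within the usual scatter, at least for this pair with this hydroxyl arrangement. No measured property shown here bears on this result.

Going by these compounds, whether a thiophene, a plain phenyl or an amine at this position would give a different number remains open.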